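This account rests on a few compounds, and the source may have more. Where it says the series, first, only, none or still open, it means among the compounds named here.

Measured in a functional assay on MCF7 cells (Homo sapiens) for antiproliferative activity, read by MTT assay, with a stated time of 48 h; a higher number here means a weaker inhibitor, a lower number a stronger inhibitor:

- compound 1 `CCCCCCCCCCCCCCCCn1cc(COC[C@@H]2OC[C@H](N)[C@@H]2O)nn1`: 3300 nM
- compound 2 `CCCCCCCCCCn1cc(COC[C@@H]2OC[C@H](N)[C@H]2O)nn1`: 45000 nM
- compound 3 `CCCCCCCCCCCCn1cc(COC[C@@H]2OC[C@H](N)[C@H]2O)nn1`: 2620 nM

Compound 3 gives 2620 nM in this assay. That is within the usual scatter of compound 1 and far lower than compound 2, so compound 3 sits at the stronger end of this small set.

The next structure is compound 4 `CCCCCCCCCCCCCCCCn1cc(COC[C@@H]2OC[C@H](N)[C@H]2O)nn1`, which differs from compound 3 by one change on the chain: butyl in place of hydrogen on a saturated chain carbon, ten or more bonds along the chain from an aromatic nitrogen.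

Among the compounds with values here, only one measured step bears on this change. Adding ethyl at that place gave a 17-fold lower number from compound 2 to compound 3 (1.23 log units; beyond the scatter), a large move towards stronger inhibition. Within the data shown here, a single step cannot show whether that trend continues as the chain grows, and no measurement yet tests it. No step beyond the scatter is therefore expected in this assay, in either direction. The estimated change is a 1.0-fold lower number from compound 3 to compound 4 (0.02 log units; within the scatter). For compound 4 the expected value is 2500 nM, with an estimated range from 1000 nM to 6500 nM.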

Compound 4, half-maximal inhibitory concentration: 2260 nM
The estimate for compound 4 lay 1.1-fold (0.04 log units) above the measured number, and the stated range covers the measured number.
By their numbers in this assay, from the lowest: compounds 4, 3 and 1 (each within the scatter of the next); then compound 2.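

Butyl in place of hydrogen on this saturated chain carbon gives a 1.2-fold lower number from compound 3 to compound 4 (0.06 log units; within the scatter) in this assay, so adding these carbons to the chain brings no change that stands out from the scatter. The hexyl step as a whole gives a 20-fold lower number from compound 2 to compound 4 (1.30 log units; beyond the scatter), which places the large move among compounds 2, 3 and 4 in the ethyl step and not in the butyl step. The stereocentre at a saturated ring carbon also shows no readable effect here, with a 1.5-fold lower number from compound 1 to compound 4 (0.16 log units; within the scatter) as a clean test of configuration alone: the fact that compounds 1 and 4 differ only in the configuration as drawn

From the compounds shown here alone, how a longer chain would behave in this position remains open, as does the effect of a carboxylic acid or an amine on the chain. It is also unknown whether the drawn configuration matters when the chain is shorter.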